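Working notes: trifluoromethyl in place of bromo

This account rests on a few compounds, and the source may have more. Where it says the series, first, only, none or still open, it means among the compounds named here.

In a functional assay on Bel-7402 cells (Homo sapiens) for antiproliferative activity, read by MTT assay, with a stated time of 72 h (on this read-out lower numbers stand for stronger inhibition and higher numbers for weaker inhibition), compound 1 (`C=C1C(=O)O[C@H]2[C@H]1CC/C(COC(=O)Cn1cc(F)c(=O)n(Cc3ccc(F)cc3)c1=O)=C\CC[C@@]1(C)O[C@@H]21`) gives 2730 nM. Compound 2 (`C=C1C(=O)O[C@H]2[C@H]1CC/C(COC(=O)Cn1cc(F)c(=O)n(Cc3ccc(Br)cc3)c1=O)=C\CC[C@@]1(C)O[C@@H]21`) gives 2670 nM in this assay. These two numbers lie within the scatter of each other, so compound 2 holds no separate rank on the data so far.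

Compound 3 (`C=C1C(=O)O[C@H]2[C@H]1CC/C(COC(=O)Cn1cc(F)c(=O)n(Cc3ccc(C(F)(F)F)cc3)c1=O)=C\CC[C@@]1(C)O[C@@H]21`) has trifluoromethyl in place of bromo on an aromatic carbon, para to a large group: trifluoromethyl in place of bromo on an aromatic carbon. The same difference reads 4-bromobenzyl to 4-(trifluoromethyl)benzyl.

For the measured compounds named here, the one measured step bearing on this change is a 1.0-fold lower number from compound 1 to compound 2 (0.01 log units; within the scatter), with bromo in place of fluoro on an aromatic carbon, and it lies within the scatter. Going by the values given here, no measured compound carries trifluoromethyl, so this basis is thin. On that single step, no change beyond the scatter is expected in this assay, and no direction is favoured. The expected size is a 1.0-fold higher number from compound 2 to compound 3 (0.00 log units; within the scatter). Compound 3 is estimated at 2700 nM, with an expected range of 1300 nM to 5500 nM.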

Compound 3, half-maximal inhibitory concentration: 2250 nM
Estimate against measurement, compound 3: 1.2-fold (0.08 log units) above, and the stated range covers the measured number.
By their numbers in this assay, from the lowest: compounds 3, 2 and 1 (each within the scatter of the next).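

Working notes on the para position: in this assay, trifluoromethyl in place of bromo gives a 1.2-fold lower number from compound 2 to compound 3 (0.07 log units; within the scatter) and trifluoromethyl in place of fluoro gives a 1.2-fold lower number from compound 1 to compound 3 (0.08 log units; within the scatter), so all three groups on this aromatic carbon now lie within the scatter of one another. The earlier pair compared only two halogens, whereas this result extends the comparison to a group of 4 heavy atoms in place of the 1 heavy atom of bromo, and even that difference in atom count does not separate the compounds on this read-out. No evidence at hand bears on why the values stay this close.

Whether an amine, a carboxylic acid or a longer alkyl chain on this carbon would give a step beyond the scatter remains open, since the three groups shown are fluoro, bromo and trifluoromethyl alone. Compound 1, compound 2 and compound 3 also share the same core and the same link to the aromatic ring, so these data say nothing about how changes in those parts would read in this assay.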